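The source may hold more compounds than are shown below. What is called first, only, known or untested is meant among the compounds shown, and "the series" means these compounds.

Measured so far:
compound 1, `NS(=O)(=O)CC(=O)NCCSc1nonc1/C(=N/O)Nc1cccc(Cl)c1`: 0.9 h in an ADME assay on isolated protein for pharmacokinetics, with UDP-glucuronosyltransferase 1A9 (Homo sapiens) as the target, read by LC-MS, with a stated time of 60 min, at 37 degrees C, tested at 1 uM, in the presence of a further agent that is not named here; a lower number here means that the compound disappears faster, a higher number that the compound lasts longer
compound 2, `N#Cc1cccc(N/C(=N\O)c2nonc2SCCNC(=O)CS(N)(=O)=O)c1`: > 3 h in this assay

For compound 2 the value in this assay is a limit, not a number, namely (the limit of > 3 h in this assay, at which 1 of the 2 values shown sits). Only a range is known for it.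

Compound 3, `NS(=O)(=O)CC(=O)NCCSc1nonc1/C(=N/O)Nc1cccc(Br)c1`, differs from compound 2 by bromo in place of cyano on an aromatic carbon. Going by the values given here, the single measured step that bears on this is an at least 3.3-fold higher number from compound 1 to compound 2 (0.52 log units; beyond the scatter), a halogen giving way to cyano; the present change runs the other way, cyano giving way to a halogen. Since compound 1 gives 0.9 h, compound 3 is expected to fall back toward that level, an expected step of an at least 3.0-fold lower number from compound 2 to compound 3 (0.47 log units; beyond the scatter). Compound 3 is estimated at 1 h, range 0.5 h to 2.5 h.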

Compound 3, half-life: 0.955 h
For compound 3 the middle estimate is 1.0-fold (0.02 log units) above the measured one, and the stated range covers the measured number.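

In this assay, bromo and chloro on this aromatic carbon read alike, with a 1.1-fold higher number from compound 1 to compound 3 (0.03 log units; within the scatter). Cyano stands apart from bromo, with an at least 3.1-fold lower number from compound 2 to compound 3 (0.49 log units; beyond the scatter). The value for compound 2 is a limit, not a number: the limit of > 3 h in this assay, at which 1 of the 3 values shown sits.

On these data alone, the full size of the step to cyano stays open. Whether cyano stands alone among the groups at this place also stays open, as the compounds shown include no amine, carboxylic acid or methoxy group there.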